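A few compounds are considered here, and "the series" means these few. Any claim that something is new, unique, unknown or untested is made for them only; others in the source may bear on it.

Measured compounds:
compound 1 `COc1ccc(/C=C/c2cc(OC)cc(OC)c2/C=C/C(=O)c2cc3ccc(Cl)cc3oc2=O)cc1` with 7360 nM in an assay on isolated protein for inhibition of Amine oxidase [flavin-containing] B (Homo sapiens), read by fluorescence, with a stated time of 15 min; a higher number here means a weaker inhibitor, a lower number a stronger inhibitor
compound 2 `COc1ccc(/C=C/c2cc(OC)cc(OC)c2/C=C/C(=O)c2cc3cccc(C)c3oc2=O)cc1` with 20000 nM in this assay
compound 3 `COc1ccc(/C=C/c2cc(OC)cc(OC)c2/C=C/C(=O)c2cc3cc(F)ccc3oc2=O)cc1` with 10200 nM in this assay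

Compound 3 holds the second highest of the three numbers in this assay; its neighbours are compound 1 at a 1.4-fold higher number from compound 1 to compound 3 (0.14 log units; within the scatter) and compound 2 at a 2.0-fold lower number from compound 2 to compound 3 (0.29 log units; within the scatter), both within the scatter. Compound 4 `COc1ccc(/C=C/c2cc(OC)cc(OC)c2/C=C/C(=O)c2cc3ccc(C)cc3oc2=O)cc1` differs from compound 3 by a group of 12 heavy atoms (10 carbon, 2 oxygen; one six-membered aromatic ring of carbon only, one six-membered aromatic ring with 1 hetero atom) in place of a group of 12 heavy atoms (9 carbon, 2 oxygen, 1 fluorine; one six-membered aromatic ring of carbon only, one six-membered aromatic ring with 1 hetero atom), on a carbonyl carbon. The bearing steps are the halogen-to-methyl swap from compound 1 to compound 2, which gave a 2.7-fold higher number from compound 1 to compound 2 (0.43 log units; beyond the scatter), and the methyl-to-fluorine swap from compound 2 to compound 3, which gave a 2.0-fold lower number from compound 2 to compound 3 (0.29 log units; within the scatter). A small rise, at the edge of the scatter, is therefore expected for compound 4 in this assay, that is a 1.4-fold higher number from compound 3 to compound 4 (0.14 log units; within the scatter). Compound 4 is estimated at 14000 nM, in the range 6000 nM to 35000 nM.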

Compound 4, half-maximal inhibitory concentration: 2780 nM
For compound 4 the middle estimate is 5.0-fold (0.70 log units) above the measured one; measured number below the stated range.
By their numbers in this assay, from the lowest: compound 4; then compounds 1, 3 and 2 (each within the scatter of the next, the first and the last beyond it).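

In this assay, methyl in place of chloro on an aromatic carbon lowers the number (a 2.6-fold lower number from compound 1 to compound 4 (0.42 log units; beyond the scatter)), and the methyl-bearing group also outdoes the fluorine-bearing one (a 3.7-fold lower number from compound 3 to compound 4 (0.56 log units; beyond the scatter)). Earlier, the only methyl compound gave the highest number, but the methyl compounds now differ widely (a 7.2-fold lower number from compound 2 to compound 4 (0.86 log units; beyond the scatter)), so among these compounds the outcome depends on where the methyl sits, not on its presence alone. Nothing measured here offers a reason for this. From the compounds shown here alone, whether an ethyl or a methoxy group on that aromatic carbon would match the methyl stays open.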